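A few compounds are considered here, and "the series" means these few. Any claim that something is new, unique, unknown or untested is made for them only; others in the source may bear on it.

Working notes on a small quinolone series in a physicochemical assay for lipophilicity, at pH 7.4; a higher number here means a more lipophilic compound, a lower number a more polar compound.

Compound 1 `COc1ccc2[nH]c(C)c(Cc3ccccc3)c(=O)c2c1` gives 2.53 in this assay. Compound 2 `Cc1[nH]c2ccc(Cl)cc2c(=O)c1Cc1ccccc1` gives 2.79. The two differ by chloro in place of methoxy on an aromatic carbon, and the step is a number 0.26 log units higher from compound 1 to compound 2 (within the scatter). Compound 3 `COc1ccc2nc(C)c(Cc3ccccc3)c(OC)c2c1` gives 4.2, the highest of the three numbers; compound 2 is nearest, compound 1 furthest, both beyond the scatter. The difference between the core of compound 3 and the core of compound 1 is not broken down here.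

Compound 4 `COc1c(Cc2ccccc2)c(C)nc2ccc(Cl)cc12` is the unmeasured member. It differs from compound 3 by chloro in place of methoxy on an aromatic carbon, the same change as from compound 1 to compound 2. A step of a number 0.30 log units higher from compound 3 to compound 4 (within the scatter) is expected because a number 0.26 log units higher from compound 1 to compound 2 (within the scatter) stayed within the scatter. Compound 4 is therefore estimated at 4.5 in this assay, between 4.1 and 4.9.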

Compound 4, distribution coefficient: 4.93
The estimate for compound 4 lay 0.43 log units below the measured number, outside the stated range (above it).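

In this assay, chloro in place of methoxy on an aromatic carbon gives a number 0.73 log units higher from compound 3 to compound 4 (beyond the scatter) on the core of compound 3, while the same change gives a number 0.26 log units higher from compound 1 to compound 2 (within the scatter) on the core of compound 1. The change therefore clears the scatter on one of these two cores and not on the other, so a step read on one core did not set the size of the step on the other. These two pairs do not show how the change would behave on any further core, and nothing available bears on the reason for the contrast.

Still open, from the compounds shown here alone, is how an amine or a carboxylic acid on that aromatic carbon would compare with chloro and methoxy on either core. Also open, going by these compounds, is whether a longer chain in place of the methyl would alter the step.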